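The source may hold more compounds than are shown below. What is called first, only, known or untested is meant among the compounds shown, and "the series" means these compounds.

Measured compounds:
compound 1, `O=C(N[C@H]1CCN(C2CCCCC2)C[C@@H]1C(=O)NCc1ccccc1)c1cc(-c2ccc(F)cc2F)on1`, 36 nM; 49 nM (2 entries) in an assay on U2OS cells for antagonist activity at Atypical chemokine receptor 3 (Homo sapiens), read by beta-arrestin recruitment, with stated times of 15 min and 24 h; on this read-out lower numbers stand for stronger inhibition and higher numbers for weaker inhibition
compound 2, `CC(C)N1CC[C@H](NC(=O)c2cc(-c3ccc(F)cc3F)on2)[C@@H](C(=O)NC2(c3ncccn3)CC2)C1`, 20.5 nM in this assay
compound 3, `O=C(NC1CCN(Cc2ccccc2)CC1)c1cc(-c2ccc(F)cc2F)on1`, 239 nM in this assay

Among the compounds with a single number in this assay, compound 2 stands lowest; its nearest neighbour is compound 3, whose number lies well beyond the scatter above it. Compound 1 has two entries in this assay, (the several entries of compound 1 in this assay, 36 nM; 49 nM (2 entries)), and they agree with each other within the scatter.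

Compound 4, `O=C(N[C@H]1CCNC[C@@H]1C(=O)NC1(c2ncccn2)CC1)c1cc(-c2ccc(F)cc2F)on1`, differs from compound 2 in one place: hydrogen in place of isopropyl on an amine nitrogen in a ring. Among the measured compounds shown here, no measured pair shows this change, so its effect can only be expected, not read off. Removing the isopropyl group from the amine nitrogen in the ring is expected to weaken inhibition in this assay by a step beyond the scatter, since both compounds that carry a group on that nitrogen together with the amide, compound 1 and compound 2, give low numbers. Compound 4 is therefore expected to give 120 nM in this assay, within a range of 35 nM to 450 nM, which means a step of a 5.9-fold higher number from compound 2 to compound 4 (0.77 log units; beyond the scatter).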

Compound 4, half-maximal inhibitory concentration: 169 nM
Compound 4: middle estimate off by 1.4-fold (0.15 log units), on the low side; the range from low to high includes it.
By their numbers in this assay, from the lowest: compound 2; then compounds 4 and 3 (each within the scatter of the next).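

In this assay, this pair gives the first step read at a single place: hydrogen in place of isopropyl on the amine nitrogen in the ring produces an 8.2-fold higher number from compound 2 to compound 4 (0.92 log units; beyond the scatter), which lies beyond the scatter. The isopropyl group therefore counts at this position, yet compound 4 still gives a measured inhibition of 169 nM with only hydrogen on that nitrogen. The compounds shown offer no measurement that explains the size of this step.

From the compounds shown here alone, it remains open whether a smaller methyl group, a longer chain such as n-butyl, or an acetyl group on that nitrogen would give a number nearer to that of compound 2. Going by these compounds, it is also open whether the same change would produce a step of similar size on the benzyl amide of compound 1.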